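The source may hold more compounds than are shown below. What is called first, only, known or untested is meant among the compounds shown, and "the series" means these compounds.

Measured in a functional assay on A549 cells (Homo sapiens) for antiproliferative activity, read by MTT assay, with a stated time of 72 h; a higher number here means a weaker inhibitor, a lower number a stronger inhibitor:
- compound 1 `NC1=NC2(CCOCC2)N(OCCCOc2ccc(F)cc2)C(N)=N1`: 1060 nM
- compound 2 `NC1=NC2(CCOCC2)N(OCCCOc2ccccc2Br)C(N)=N1`: 160 nM

Going by the values given here, compound 2 holds the lower of the two numbers, and the only measured step is a 6.6-fold lower number from compound 1 to compound 2 (0.82 log units; beyond the scatter). Next is compound 3 `NC1=NC2(CCOCC2)N(OCCCOc2cccc(Br)c2)C(N)=N1`, which carries 3-bromophenyl in place of 2-bromophenyl on an oxygen on a saturated carbon. Among the compounds with values here, the measured step exchanged 4-fluorophenyl for 2-bromophenyl, so no measured pair isolates this change of bromine placement. A smaller shift than that step is expected in this assay, towards a higher number. The expected size is a 1.6-fold higher number from compound 2 to compound 3 (0.21 log units; within the scatter). For compound 3 the estimate is 260 nM, with an expected range of 90 nM to 750 nM.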

Compound 3, half-maximal inhibitory concentration: 160 nM
For compound 3 the middle estimate is 1.6-fold (0.21 log units) above the measured one; low and high end bracket the measured number.
By their numbers in this assay, from the lowest: compounds 2 and 3 (each within the scatter of the next); then compound 1.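

On an oxygen on a saturated carbon, 2-bromophenyl and 3-bromophenyl are not told apart in this assay, with no change at the digits printed from compound 2 to compound 3 (within the scatter). The replacement of 4-fluorophenyl by 3-bromophenyl gives a 6.6-fold lower number from compound 1 to compound 3 (0.82 log units; beyond the scatter), so the gap to compound 1 holds for both bromophenyl compounds. Nothing on hand offers a reason for this result.

Halogen and its placement remain entangled in the steps from compound 1, and 4-bromophenyl would separate them. From the compounds shown here alone, how an amine or a carboxylic acid on the phenyl ring, or a longer chain, would read here also remains open.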